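Acid in Place of Alkene on the Amide Nitrogen

The compounds below may be only part of what the source reports. "The series", "measured", "known", "first", "only" and "open" are said of these compounds alone.

Three compounds sharing one core were measured in an assay on cells for agonist activity at vitamin D3 receptor (Homo sapiens), with a stated time of 96 h; a lower number here means that less compound is needed, a higher number that more compound is needed for the effect. Compound 1 `CCN(CC)CCNC(=O)c1ccc(C(CC)(CC)c2ccc(OCCC(O)(CC)CC)c(C)c2)n1CC` gives 2.3 nM, and compound 3 `CCn1c(C(=O)N(C)CC(=O)O)ccc1C(CC)(CC)c1ccc(OCCC(O)(CC)CC)c(C)c1` gives 89 nM. For compound 2 `C=CCN(C)C(=O)c1ccc(C(CC)(CC)c2ccc(OCCC(O)(CC)CC)c(C)c2)n1CC` the assay reports only a limit, > 10000 nM, so compound 2 sits at the weak end of the set (the limit of > 10000 nM in this assay, at which 1 of the 3 values shown sits). The unmeasured compound 4 `CCn1c(C(=O)NC(C)C(=O)O)ccc1C(CC)(CC)c1ccc(OCCC(O)(CC)CC)c(C)c1` differs from compound 2 by (1-carboxyethyl)amino in place of allyl(methyl)amino on a carbonyl carbon. The closest measured step is an at least 110-fold lower number from compound 2 to compound 3 (2.05 log units; beyond the scatter), which likewise introduces a carboxy group; the steps of an at least 4300-fold higher number from compound 1 to compound 2 (3.63 log units; beyond the scatter) and a 39-fold higher number from compound 1 to compound 3 (1.59 log units; beyond the scatter) frame the same three compounds. For compound 4 a large fall in the number is therefore expected, an at least 66-fold lower number from compound 2 to compound 4 (1.82 log units; beyond the scatter). Compound 4 is estimated at 150 nM, within a range from 30 nM to 800 nM.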

Compound 4, half-maximal effective concentration: 66 nM
Beside the measured number, compound 4's estimate is 2.3-fold (0.36 log units) above it; the measured number falls inside the stated range.
By their numbers in this assay, from the lowest: compound 1; then compounds 4 and 3 (each within the scatter of the next). At a limit, above all of these: compound 2.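

The gain from compound 2 is not tied to one acid-bearing group: (1-carboxyethyl)amino on the carbonyl carbon also gives a large fall (an at least 150-fold lower number from compound 2 to compound 4 (2.18 log units; beyond the scatter)). Compound 2 holds only a limit, so that step is a bound, not an exact size: (the limit of > 10000 nM in this assay, at which 1 of the 4 values shown sits). The two acid-bearing amides cannot be told apart (a 1.3-fold lower number from compound 3 to compound 4 (0.13 log units; within the scatter)), and the acid in compound 4 stays well short of the 2-(diethylamino)ethyl group (a 29-fold higher number from compound 1 to compound 4 (1.46 log units; beyond the scatter)).

Still open, from the compounds shown here alone, is whether an ester in place of the carboxylic acid, or a longer chain carrying the acid, would hold this level. Also open, going by these compounds, is whether a shorter chain ending in a dimethylamine would match compound 1.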